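This account rests on a few compounds, and the source may have more. Where it says the series, first, only, none or still open, it means among the compounds named here.

Working notes on the series, cytotoxicity arm.

Compound 1 `O=c1c(O)c(-c2ccccc2)oc2cc(OCc3ccccc3Br)cc(O)c12` is the reference. In an ADME assay on Huh-5-2 cells (Homo sapiens) for cytotoxicity, read by WST assay, with a stated time of 3 days (a higher number here means that more compound is tolerated, a lower number that less compound is tolerated), compound 1 gives > 100000 nM, which is a limit of the assay and not a number. Compound 2 `COc1ccccc1COc1cc(O)c2c(=O)c(O)c(-c3ccccc3)oc2c1` gives > 100000 nM in this assay, again a limit. Compound 3 `O=c1c(O)c(-c2ccccc2)oc2cc(OCc3cccc(Br)c3)cc(O)c12` gives > 100000 nM in this assay, likewise a limit. The three measured steps are therefore unreadable: a step that the two limits leave unreadable from compound 1 to compound 2, a step that the two limits leave unreadable from compound 1 to compound 3 and a step that the two limits leave unreadable from compound 2 to compound 3. All that can be said is the limit of > 100000 nM in this assay, at which 3 of the 3 values shown sit, so no direction or size can be taken from the measured changes at the benzyl-type position.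

Compound 4 `O=c1c(O)c(-c2ccccc2)oc2cc(OCc3ccc([N+](=O)[O-])cc3)cc(O)c12` is the next member. Its change from compound 1 is 4-nitrophenyl in place of 2-bromophenyl on a saturated chain carbon bound to an oxygen on an aromatic ring. The measured steps bear on it only in that every variation at the same place, whether methoxy in place of bromo or 3-bromophenyl in place of 2-bromophenyl or 2-methoxyphenyl, has stayed at the limit. Compound 4 is therefore expected to sit at the same limit, with an expected step of a number no higher from compound 1 to compound 4 (the limit leaves the size open). Compound 4 is estimated at 100000 nM, range 50000 nM to 200000 nM.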

Compound 4, half-maximal cytotoxic concentration: 93000 nM
The estimate for compound 4 lay 1.1-fold (0.03 log units) above the measured number; low and high end bracket the measured number.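

In this assay compound 4 gives 93000 nM, the first result at this position that is a number. The other compounds stay at a limit of the assay: the limit of > 100000 nM in this assay, at which 3 of the 4 values shown sit. Among the compounds shown here, the change to 4-nitrophenyl therefore gives the first readable steps: an at least 1.0-fold lower number from compound 1 to compound 4 (0.03 log units; that floor lies within the scatter), an at least 1.0-fold lower number from compound 3 to compound 4 (0.03 log units; that floor lies within the scatter) and an at least 1.0-fold lower number from compound 2 to compound 4 (0.03 log units; that floor lies within the scatter). From the compounds shown here alone, each of these is only a floor within the scatter, so 2-bromobenzyl to 4-nitrobenzyl shows no established fall in the tolerated concentration, and the real size of each step remains unknown.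

Going by these compounds, it remains open whether the readable number belongs to the nitro group specifically or to the 4-nitrobenzyl group as a whole. On these data alone, how an amine or a carboxylic acid in place of the nitro group would read in this assay is also open.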